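The source may report more compounds than this note shows. Statements on the series, on what has been measured and on what is new or still open speak of the compounds shown alone.

Compound 1 `Cc1oncc1NS(=O)(=O)c1ccc(F)c2ncc(I)cc12` gives 2100 nM in an assay for inhibition of methylcytosine dioxygenase TET2 (Homo sapiens), read by mass spectrometry, with stated times of 30 min and 1 h; a higher number here means a weaker inhibitor, a lower number a stronger inhibitor. Compound 2 `NS(=O)(=O)c1ccc(F)c2ncc(I)cc12`, with hydrogen in place of the 5-methyl-1,2-oxazol-4-yl on the sulfonamide nitrogen, gives 86600 nM in this assay, a step of a 41-fold higher number from compound 1 to compound 2 (1.62 log units; beyond the scatter). Compound 3 `O=S(=O)(NC1CCCCC1)c1ccc(F)c2ncc(I)cc12`, carrying cyclohexyl on that nitrogen, returns only a limit in this assay, > 200000 nM, which is the limit of > 200000 nM in this assay, at which 1 of the 3 values shown sits. Compound 3 thus stands at the weak end of the three: the step from compound 1 is an at least 95-fold higher number from compound 1 to compound 3 (1.97 log units; beyond the scatter), and from compound 2 it is an at least 2.3-fold higher number from compound 2 to compound 3 (0.36 log units; beyond the scatter).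

Compound 4 `COc1cccc(NS(=O)(=O)c2ccc(F)c3ncc(I)cc23)c1` differs from compound 3 by 3-methoxyphenyl in place of cyclohexyl on a sulfonamide nitrogen. The one aromatic substituent measured on this nitrogen, in compound 1, sits far below the cyclohexyl of compound 3, by an at least 95-fold higher number from compound 1 to compound 3 (1.97 log units; beyond the scatter), and far below the bare sulfonamide of compound 2 as well, by a 41-fold higher number from compound 1 to compound 2 (1.62 log units; beyond the scatter). Compound 4 returns to an aromatic substituent, so a large fall in this assay is expected, with the estimated step being an at least 33-fold lower number from compound 3 to compound 4 (1.52 log units; beyond the scatter). Compound 4 is therefore estimated at 6000 nM in this assay, within a range of 1000 nM to 50000 nM.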

Compound 4, half-maximal inhibitory concentration: > 200000 nM
Compound 4 gave a limit, no number; the forecaster's own chance of this, stated with the estimate: 10%; at least 33-fold (1.52 log units) between middle value and limit.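

On the sulfonamide nitrogen, an aromatic substituent alone does not bring a low number in this assay: 3-methoxyphenyl in place of 5-methyl-1,2-oxazol-4-yl gives an at least 95-fold higher number from compound 1 to compound 4 (1.97 log units; beyond the scatter), and 3-methoxyphenyl in place of hydrogen gives an at least 2.3-fold higher number from compound 2 to compound 4 (0.36 log units; beyond the scatter). The step between compound 3 and compound 4 cannot be read, since both values are limits, so 3-methoxyphenyl and cyclohexyl cannot be put in order. Of the substituents shown, only the 5-methyl-1,2-oxazol-4-yl of compound 1 and the hydrogen of compound 2 give a number rather than a limit, and the limit now covers two compounds: the limit of > 200000 nM in this assay, at which 2 of the 4 values shown sit.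

The compounds shown leave open whether the lower number of compound 1 depends on its methyl group or on its ring. They also leave open how an unsubstituted phenyl, a pyridine or a carboxylic acid on the aromatic ring would stand on this nitrogen.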